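Swapping fluoro for methylcarbamoyl on a poorly soluble compound

The source may hold more compounds than are shown below. What is called first, only, known or untested is meant among the compounds shown, and "the series" means these compounds.

Measured in a physicochemical assay for solubility, read by nephelometry; on this read-out lower numbers stand for lower solubility and higher numbers for higher solubility:
- Compound 1 `CC1(C)C(=O)N(c2ccc(SC(F)(F)F)cc2)C(=O)N1Cc1ccnc(N2CCNCC2)c1`: < 0.024 ug/mL, a limit of the assay and not a number
- Compound 2 `CC1(C)C(=O)N(c2ccc(SC(F)(F)F)cc2)C(=O)N1Cc1ccnc(C(=O)O)c1`: 0.142 ug/mL
- Compound 3 `CC1(C)C(=O)N(c2ccc(SC(F)(F)F)cc2)C(=O)N1Cc1ccnc(F)c1`: 0.032 ug/mL

Of the two true numbers, the lower belongs to compound 3 at 0.032 ug/mL. Compound 4 `CNC(=O)c1cc(CN2C(=O)N(c3ccc(SC(F)(F)F)cc3)C(=O)C2(C)C)ccn1` differs from it in one group: methylcarbamoyl in place of fluoro on an aromatic carbon, next to the ring nitrogen. Among the compounds with values here, no measured step makes this exact change. The nearest guide is the carboxy group on that same carbon, with a 4.4-fold lower number from compound 2 to compound 3 (0.65 log units; beyond the scatter). The step of an at least 1.3-fold higher number from compound 1 to compound 3 (0.12 log units; that floor lies within the scatter) offers only a floor within the scatter. A small rise in this assay is therefore expected, smaller than the carboxy step and near the edge of the scatter. The estimated change is a 1.9-fold higher number from compound 3 to compound 4 (0.27 log units; within the scatter). For compound 4 the estimate is 0.06 ug/mL, with an expected range from 0.02 ug/mL to 0.2 ug/mL.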

Compound 4, solubility: < 0.023 ug/mL
Compound 4: only a limit was reported (the forecaster's own chance of this, stated with the estimate: 15%); at least 2.6-fold (0.41 log units) between middle value and limit.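

In this assay compound 4 gives < 0.023 ug/mL, a limit of the assay and not a number. On this aromatic carbon, the methylcarbamoyl group does not keep what the carboxy group shows: methylamino in place of hydroxy gives an at least 6.1-fold lower number from compound 2 to compound 4 (0.79 log units; beyond the scatter). Against fluoro the change gives only an at least 1.3-fold lower number from compound 3 to compound 4 (0.14 log units; that floor lies within the scatter), so these two groups cannot be told apart here, and the steps to compound 1 cannot be read.

Going by these compounds, whether a hydroxymethyl group or an unsubstituted carboxamide on this carbon would read clear of the limit stays open. So does how far under its limit compound 4 truly lies.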